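The compounds below may be only part of what the source reports. "The series", "measured", "known", "first", "only" and "open" are said of these compounds alone.

Measured in a functional assay on HCT-116 cells (Homo sapiens) for inhibition, read by MTT assay, with a stated time of 96 h; a lower number here means a stronger inhibitor of growth, a higher number a weaker inhibitor of growth:
compound 1 `CC(=O)SCCCCCCNC(=O)c1cc(-c2ccncc2)n[nH]1`: 41100 nM
compound 2 `O=C(NCCCCCCS)c1ccn[nH]1`: > 50000 nM, a limit of the assay

Among the compounds with values here, compound 1 holds the only actual number here, since compound 2 reached only (the limit of > 50000 nM in this assay, at which 1 of the 2 values shown sits). Compound 3 `CCC(=O)SCCCCCCNC(=O)c1cc(-c2ccncc2)n[nH]1` differs from compound 1 by methyl in place of hydrogen on a saturated chain carbon bound to a carbonyl carbon. Within the data shown here, no measured pair isolates this change, so the step is expected to stay within the usual scatter, with no direction favoured. Compound 3 is therefore estimated at 41000 nM, between 15000 nM and 100000 nM. That estimate means an expected step of a 1.0-fold lower number from compound 1 to compound 3 (0.00 log units; within the scatter), small enough to sit inside the scatter of repeated measurements.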

Compound 3, concentration for 50% growth inhibition: > 50000 nM
Compound 3: a limit, no number (the forecaster's own chance of this, stated with the estimate: 35%); middle value at least 1.2-fold (0.08 log units) from the limit.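

In this assay, the change from acetylsulfanyl to propanoylsulfanyl gives an at least 1.2-fold higher number from compound 1 to compound 3 (0.08 log units; that floor lies within the scatter), so methyl on this saturated chain carbon bound to a carbonyl carbon brings no stronger growth inhibition. Compound 3 gives > 50000 nM, which is a limit of the assay and not a number. The full size of the step remains unknown, because only compound 1 has an actual number: the limit of > 50000 nM in this assay, at which 2 of the 3 values shown sit.

From the compounds shown here alone, it remains open how far the step extends past its floor. Also open, going by these compounds, is whether a benzoyl group in place of the acetyl would give a measurable value.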